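Reshaping the side-chain amide of compound 1

This account rests on a few compounds, and the source may have more. Where it says the series, first, only, none or still open, it means among the compounds named here.

Compound 1 `CCCCc1oc2ccccc2c1C(=O)c1ccc(OCC(=O)NC(C)C)cc1` gives 360 nM in a functional assay on HL-60 cells (Homo sapiens) for antiproliferative activity, read by MTT assay, with a stated time of 24 h; on this read-out higher numbers stand for weaker inhibition and lower numbers for stronger inhibition.
Compound 2 `CCCCc1oc2ccccc2c1C(=O)c1ccc(OCC(=O)Nc2ccccc2)cc1` gives > 50000 nM in this assay, which is a limit of the assay and not a number.
Compound 3 `CCCCc1oc2ccccc2c1C(=O)c1ccc(OCC(=O)N[C@H](C)c2ccccc2)cc1` gives > 50000 nM in this assay, also a limit and not a number.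

Going by the values given here, compound 1 therefore holds the only actual number in this small set; compounds 2 and 3 each sit at the limit of > 50000 nM in this assay, at which 2 of the 3 values shown sit. The untested compound 4 `CCCCc1oc2ccccc2c1C(=O)c1ccc(OCCCC(=O)N2CCCCC2)cc1` differs from compound 1 at the amide end of the ether side chain: 2-((piperidin-1-yl)carbonyl)ethyl in place of isopropylcarbamoyl on a saturated chain carbon bound to an oxygen on an aromatic ring. The amide hydrogen is gone, the chain is longer, and the nitrogen now carries a six-membered non-aromatic ring.

The two measured steps that bear on this are both changes at the amide nitrogen of compound 1. There was an at least 130-fold higher number from compound 1 to compound 2 (2.14 log units; beyond the scatter) and an at least 130-fold higher number from compound 1 to compound 3 (2.14 log units; beyond the scatter); the step that the two limits leave unreadable from compound 2 to compound 3 cannot be read. Both measured changes put a phenyl-containing group on that nitrogen and lost almost all activity. Compound 4 brings no phenyl, but it does replace the small isopropyl with a larger, cyclic group and removes the hydrogen-bond donor, so a step toward higher numbers is expected, though probably not as large: a 14-fold higher number from compound 1 to compound 4 (1.14 log units; beyond the scatter). Compound 4 is estimated at 5000 nM, within a range of 800 nM to 50000 nM.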

Compound 4, half-maximal inhibitory concentration: 31900 nM
Estimate against measurement, compound 4: 6.4-fold (0.80 log units) below; the range from low to high includes it.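

In this assay, a change at the amide end of the side chain that brings in no phenyl group still gives a large step, an 89-fold higher number from compound 1 to compound 4 (1.95 log units; beyond the scatter). A phenyl group is therefore not needed for a large rise at this position, since the group entering here carries a six-membered non-aromatic ring on a longer chain and has no amide hydrogen. Set against the two phenyl-bearing amides, the new value gives an at least 1.5-fold lower number from compound 3 to compound 4 (0.19 log units; that floor lies within the scatter) and an at least 1.5-fold lower number from compound 2 to compound 4 (0.19 log units; that floor lies within the scatter), and compounds 2 and 3 each stay at a limit of the assay and not a number: the limit of > 50000 nM in this assay, at which 2 of the 4 values shown sit.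

The ring, the longer chain and the loss of the amide hydrogen all arrive in one change, so the compounds shown leave open which of them matters, and an isopropylcarbamoyl group on the longer chain of compound 4 or a (piperidin-1-yl)carbonyl group on the shorter chain of compound 1 would pull them apart. Also open, as far as these compounds go, are smaller groups on the amide nitrogen, such as cyclopropyl or methyl, or a carboxylic acid at the chain end, and the steps between limits cannot be read.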